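A new side chain on the core of compound 2

A few compounds are considered here, and "the series" means these few. Any claim that something is new, unique, unknown or untested is made for them only; others in the source may bear on it.

Among the compounds with values here, in a functional assay on MCF7 cells (Homo sapiens) for inhibition, read by fluorescence, with a stated time of 72 h (on this read-out lower numbers stand for stronger inhibition and higher numbers for weaker inhibition), compound 2 (`CC[C@@H](CO)Nc1nc(NC(=N)N)c2ncn(C(C)C)c2n1`) gives 1600 nM and holds the lower of the two numbers so far, while compound 1 (`CC(C)n1cnc2c(NC(=N)N)nc(NCCO)nc21`) gives 12400 nM as the higher one. Within the data shown here, the one measured step (a 7.8-fold lower number from compound 1 to compound 2 (0.89 log units; beyond the scatter)) came from ethyl in place of hydrogen on a saturated chain carbon, so a small edit to this side chain can already move the number beyond the scatter. Compound 3 (`CC(C)[C@H](N)COc1nc(NC(=N)N)c2ncn(C(C)C)c2n1`) carries 2-amino-3-methylbutoxy in place of (1-(hydroxymethyl)propyl)amino on an aromatic carbon. Among the measured compounds shown here, no measured step makes such a swap, so that earlier step serves only as a guide to size, and the data give no direction in this assay. The expected step (a 1.2-fold lower number from compound 2 to compound 3 (0.09 log units; within the scatter)) lies within the scatter, with a wide margin either way. For compound 3 the estimated value is 1300 nM (expected range 280 nM to 6000 nM).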

Compound 3, half-maximal inhibitory concentration: 3400 nM
Compound 3: middle estimate off by 2.6-fold (0.42 log units), on the low side; low and high end bracket the measured number.
By their numbers in this assay, from the lowest: compound 2; then compound 3; then compound 1.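

In this assay the swap to 2-amino-3-methylbutoxy on the aromatic carbon between two ring nitrogen atoms gives a 2.1-fold higher number from compound 2 to compound 3 (0.33 log units; beyond the scatter), so this position still accepts a chain joined through oxygen and carrying an amino group, though here it gives up some of what compound 2 reached. Set against the shorter (2-hydroxyethyl)amino chain, the same group gives a 3.6-fold lower number from compound 1 to compound 3 (0.56 log units; beyond the scatter), which places the new chain in the middle of the three. Nothing available accounts for either step.

Going by these compounds, the swap changes the linking atom, the chain's branching and its end group all at once, so which of these moves the number remains open. A 2-amino-3-methylbutylamino chain, with nitrogen as the link and the amine kept, would separate the linking atom from the rest.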